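Working notes: hydroxy to methoxy step

The compounds below may be only part of what the source reports. "The series", "measured", "known", "first", "only" and "open" are said of these compounds alone.

In a functional assay on HL-60 cells (Homo sapiens) for cytotoxicity, read by WST assay, with a stated time of 48 h (on this read-out lower numbers stand for an effect already at smaller amounts and higher numbers for an effect only at larger amounts of compound), compound 1 (`O=C1OC[C@H](Cc2ccccc2)[C@H]1Cc1ccccc1`) gives 77000 nM and compound 2 (`Cc1cccc(C[C@H]2C(=O)OC[C@@H]2Cc2ccccc2)c1`) gives 53000 nM on the same scale. Compound 3 (`O=C1OC[C@H](Cc2ccccc2)[C@H]1Cc1ccc(O)cc1`) gives 88000 nM and stands within the scatter of both. Compound 4 (`COc1ccc(C[C@H]2C(=O)OC[C@@H]2Cc2ccccc2)cc1`) differs from compound 3 by methyl in place of hydrogen on an oxygen on an aromatic ring as methyl in place of hydrogen on an oxygen on an aromatic ring, that is, hydroxy to methoxy. Going by the values given here, no measured step makes this exact change. The closest are a 1.1-fold higher number from compound 1 to compound 3 (0.06 log units; within the scatter) for the hydroxy and a 1.5-fold lower number from compound 1 to compound 2 (0.16 log units; within the scatter) for a methyl on an aromatic carbon, and a 1.7-fold higher number from compound 2 to compound 3 (0.22 log units; within the scatter) also stays small. The expected 1.4-fold lower number from compound 3 to compound 4 (0.13 log units; within the scatter) in this assay is therefore no real shift. Compound 4 is estimated at 65000 nM (expected range 30000 nM to 120000 nM).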

Compound 4, half-maximal effective concentration: 67000 nM
Compound 4: the middle estimate sits 1.0-fold (0.01 log units) below what was measured; low and high end bracket the measured number.
By their numbers in this assay, from the lowest: compounds 2, 4, 1 and 3 (each within the scatter of the next).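

In this assay methyl on the oxygen on the aromatic ring gives a 1.3-fold lower number from compound 3 to compound 4 (0.12 log units; within the scatter) and so stays within the scatter. Against the unsubstituted ring, methoxy gives a 1.1-fold lower number from compound 1 to compound 4 (0.06 log units; within the scatter) and also stays within the scatter. Hydrogen, hydroxy and methoxy at this place on the ring therefore cannot be told apart on this read-out, and a free hydroxy hydrogen is not needed to hold the number in this range.

No supporting evidence bears on this result. From the compounds shown here alone, whether an amine, a carboxylic acid or a longer chain on this oxygen would give a step beyond the scatter stays open.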